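A Carboxylic Acid Chain Replaces the Heptyloxy Group

This account rests on a few compounds, and the source may have more. Where it says the series, first, only, none or still open, it means among the compounds named here.

Three compounds share a core that carries two phenyl groups and one variable side chain. Compound 1 `CCCCCCCCCn1nc(-c2ccccc2)c(-c2ccccc2)cc1=O`, compound 2 `CCCCCCCOc1cc(-c2ccccc2)c(-c2ccccc2)nn1` and compound 3 `CCCCCCCCS(=O)(=O)c1cc(-c2ccccc2)c(-c2ccccc2)nn1` were all tested in an assay on microsomes from liver for inhibition of sterol O-acyltransferase 1 (Rattus norvegicus); a higher number here means a weaker inhibitor, a lower number a stronger inhibitor. Compound 1 gives 85000 nM, compound 2 gives 58000 nM and compound 3 gives 36000 nM. Among these three numbers, compound 2 holds the middle one; its gap to compound 1 and its gap to compound 3 both lie within the usual scatter of repeated measurements, so none of the three can be called stronger or weaker than another on this evidence.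

Compound 4 `O=C(O)CCCCCSc1cc(-c2ccccc2)c(-c2ccccc2)nn1` has not yet been measured. It differs from compound 2 in one place: (5-carboxypentyl)sulfanyl in place of heptyloxy on an aromatic carbon. Within the data shown here, no pair of measured compounds that differ in a single place is available, so the size of this step cannot be read from an earlier example; the three measured numbers show only that changing the side chain has so far moved the result little. The expected step in this assay is a 1.6-fold higher number from compound 2 to compound 4 (0.19 log units; within the scatter), a small move toward a weaker inhibitor if anything, possibly none beyond the scatter. Compound 4 is therefore expected to give 90000 nM, with a range from 25000 nM to 350000 nM.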

Compound 4, half-maximal inhibitory concentration: > 300000 nM
Compound 4 ended at the assay's limit; the forecaster's own chance of this, stated with the estimate: 30%; at least 3.3-fold (0.52 log units) between middle value and limit.
By their numbers in this assay, from the lowest: compounds 3, 2 and 1 (each within the scatter of the next, the first and the last beyond it). At a limit, above all of these: compound 4.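

Replacing heptyloxy with (5-carboxypentyl)sulfanyl on this aromatic carbon, next to the ring nitrogen, gives an at least 5.1-fold higher number from compound 2 to compound 4 (0.71 log units; beyond the scatter) in this assay, and this is the only step shown so far between compounds that differ in one place. The earlier compounds shown here differ in more than one place, so they could not show that a single change at this position can leave a much weaker inhibitor; this position does not accept every side chain equally. The full size of the step remains unknown because compound 4 sits at a limit of the assay, not at a number: the limit of > 300000 nM in this assay, at which 1 of the 4 values shown sits.

The step changes the linking atom from oxygen to sulfur and places a carboxylic acid at the end of the chain in one move, and the compounds shown do not separate these two parts. A plain heptylsulfanyl chain without the acid, or a carboxylic acid on an oxygen-linked chain, would begin to separate them, and an ester or an amine at the chain end would show whether the acid itself matters.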